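This account rests on a few compounds, and the source may have more. Where it says the series, first, only, none or still open, it means among the compounds named here.

Measured so far in a functional assay on MCF7 cells (Homo sapiens) for cytotoxicity, read by MTT assay, with a stated time of 48 h; a higher number here means a weaker inhibitor, a lower number a stronger inhibitor:
- compound 1 `COc1ccc(-c2nnc(SCCn3c([N+](=O)[O-])cnc3C)o2)cc1` gives 10600 nM
- compound 2 `Cc1ncc([N+](=O)[O-])n1CCSc1nnc(-c2ccc(F)cc2)o1` gives 8100 nM
- compound 3 `Cc1ncc([N+](=O)[O-])n1CCSc1nnc(-c2ccccc2O)o1` gives 28300 nM

Compound 3 holds the highest of the three numbers, with both other compounds lower by more than the scatter. The next compound is compound 4 `Cc1ncc([N+](=O)[O-])n1CCSc1nnc(-c2cccnc2)o1`, which has pyridin-3-yl in place of 2-hydroxyphenyl on an aromatic carbon.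

Among the compounds with values here, three measured steps bear on this change. Two of them bring in the 2-hydroxyphenyl group that compound 4 loses (a 2.7-fold higher number from compound 1 to compound 3 (0.43 log units; beyond the scatter)) and (a 3.5-fold higher number from compound 2 to compound 3 (0.54 log units; beyond the scatter)). The third, between the two other aryl groups, stays within the scatter (a 1.3-fold lower number from compound 1 to compound 2 (0.12 log units; within the scatter)). Within the data shown here, no measured compound carries pyridin-3-yl, so this comparison is indirect. A modest move to a lower number is expected, of about the size of those two steps or somewhat less (a 2.0-fold lower number from compound 3 to compound 4 (0.31 log units; beyond the scatter)). For compound 4 the estimate is 14000 nM with an expected range from 6500 nM to 28000 nM in this assay when measured.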

Compound 4, half-maximal inhibitory concentration: 28700 nM
Beside the measured number, compound 4's estimate is 2.1-fold (0.31 log units) below it; measured number above the stated range.
By their numbers in this assay, from the lowest: compounds 2 and 1 (each within the scatter of the next); then compounds 3 and 4 (each within the scatter of the next).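

In this assay, on the aromatic carbon of the five-membered ring, pyridin-3-yl and 2-hydroxyphenyl stand level (a 1.0-fold higher number from compound 3 to compound 4 (0.01 log units; within the scatter)), although one group has a hydrogen-bond donor and the other has none. Compound 4 also sits beyond the scatter from the two 4-substituted phenyl compounds (a 3.5-fold higher number from compound 2 to compound 4 (0.55 log units; beyond the scatter); a 2.7-fold higher number from compound 1 to compound 4 (0.43 log units; beyond the scatter)), so the four compounds form two pairs, with 4-fluorophenyl and 4-methoxyphenyl giving the lower numbers. Nothing available explains this split or the match within either pair.

The compounds shown leave open whether the higher pair reflects the ring nitrogen and hydroxyl themselves or where they sit, which pyridin-4-yl and 4-hydroxyphenyl could test. As far as these compounds go, whether a 4-aminophenyl or 4-carboxyphenyl group would join either pair also remains unknown.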